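Second instance of one aryl swap: estimate for compound 4

A few compounds are considered here, and "the series" means these few. Any claim that something is new, unique, unknown or untested is made for them only; others in the source may bear on it.

Compound 1 `Clc1cccc(Cn2cc(COc3ccccc3)nn2)c1` and compound 3 `Clc1ccc(OCc2cn(Cc3cccc(Cl)c3)nn2)cc1` share a core and differ only as set out in chloro in place of hydrogen on an aromatic carbon. In a physicochemical assay, read by spectrophotometry, with a stated time of 30 min (a higher number here means a weaker inhibitor, a lower number a stronger inhibitor), compound 1 gives 27.3 ug/mL, while compound 3 gives 23.3 ug/mL; the step between them is a 1.2-fold lower number from compound 1 to compound 3 (0.07 log units; within the scatter).

Compound 2 `Brc1ccc(Cn2cc(COc3ccccc3)nn2)cc1` is obtained from compound 1 by the change (4-bromophenyl in place of 3-chlorophenyl on a saturated chain carbon bound to an aromatic nitrogen). In this assay compound 2 gives 18.3 ug/mL, a step of a 1.5-fold lower number from compound 1 to compound 2 (0.17 log units; within the scatter) from compound 1. Within the data shown here, this is the only measured instance of that change, and it lies within the scatter, so it gives no firm direction. Compound 2 and compound 3 also lie within the scatter of each other.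

Compound 4 `Clc1ccc(OCc2cn(Cc3ccc(Br)cc3)nn2)cc1`, not yet measured, stands to compound 3 as compound 2 stands to compound 1: the change is 4-bromophenyl in place of 3-chlorophenyl on a saturated chain carbon bound to an aromatic nitrogen, and the place is described in the same words as before, so the two changes are the same. The core on which it is made differs from that of compound 1 only by chloro in place of hydrogen on an aromatic carbon, a difference whose own step was small.

In this assay, among the measured compounds shown here, the expected step is a 1.5-fold lower number from compound 3 to compound 4 (0.16 log units; within the scatter), resting on the single measured instance of the change, a 1.5-fold lower number from compound 1 to compound 2 (0.17 log units; within the scatter). Compound 4 is therefore expected to give 16 ug/mL, with a range estimated from 9 ug/mL to 28 ug/mL.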

Compound 4, half-maximal inhibitory concentration: 11 ug/mL
For compound 4 the middle estimate is 1.5-fold (0.16 log units) above the measured one; measured number inside the range.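

In this assay, the swap to 4-bromophenyl in place of 3-chlorophenyl on a saturated chain carbon bound to an aromatic nitrogen now gives a 2.1-fold lower number from compound 3 to compound 4 (0.33 log units; beyond the scatter); this points the same way as a 1.5-fold lower number from compound 1 to compound 2 (0.17 log units; within the scatter), which alone gave no firm direction, so across these two cores the change keeps its sign and reaches beyond the scatter once, and only modestly. The chloro in place of hydrogen on an aromatic carbon gives a 1.7-fold lower number from compound 2 to compound 4 (0.22 log units; within the scatter), which, like the earlier step for that change on the 3-chlorophenyl side, stays within the scatter, and these two instances of the aryl swap, one on each core, do not show that its size depends on the core or that it would carry to any further core. Nothing available here bears on why the swap lowers the number.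

Open, as far as these compounds go, is how much of the step belongs to the halogen and how much to its position, which 4-chlorophenyl or 3-bromophenyl in the same place would separate. Also open, from the compounds shown here alone, is whether the step holds when the chloro on the aromatic carbon gives way to a methoxy group or a carboxylic acid.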